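A few compounds are considered here, and "the series" means these few. Any claim that something is new, unique, unknown or untested is made for them only; others in the source may bear on it.

Compound 1, `CCCc1nc(-c2ccccc2)c(CNCCCN2CCN(c3ccccc3F)CC2)o1`: in an assay on HEK293 cells for inhibition of Voltage-dependent T-type calcium channel subunit alpha-1G (Homo sapiens), read by patch clamp (on this read-out lower numbers stand for stronger inhibition and higher numbers for weaker inhibition), compound 1 gives 16100 nM.
Compound 2, `CCCc1nc(-c2ccccc2)c(CNCCCN2CCN(c3cccc(C)c3)CC2)o1`: in this assay compound 2 gives 1190 nM.
Compound 3, `CCCc1nc(-c2ccccc2)c(CNCCN2CCN(c3ccc(Cl)cc3)CC2)o1`: in this assay compound 3 gives 2820 nM.

Among these three, compound 3 holds the second highest number. Compound 2 sits below it and compound 1 above it, and both of those gaps are wider than the usual scatter, so compound 3 is set apart from each of its neighbours. Among the measured compounds shown here, the only step between measured compounds that differ in one place is a 14-fold lower number from compound 1 to compound 2 (1.13 log units; beyond the scatter); it concerns a swap of one aryl group for another on the amine nitrogen in a ring, not the change now in question, and so gives no direct guidance here.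

Compound 4, `CCCc1nc(-c2ccccc2)c(CNCCN2CCN(c3ccc(F)cc3)CC2)o1`, differs from compound 3 by fluoro in place of chloro on an aromatic carbon. For the measured compounds named here, no measured pair in this set shows a halogen swap of this kind, so the expectation rests on the size of the change alone: a single heavy atom replaced by another, without any gain or loss of ring, donor, acceptor or charge. Compound 4 is therefore expected to move little in this assay, with a step of about a 1.4-fold higher number from compound 3 to compound 4 (0.15 log units; within the scatter), and its estimated value is 4000 nM, within a range of 1500 nM to 11000 nM.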

Compound 4, half-maximal inhibitory concentration: 7080 nM
For compound 4 the middle estimate is 1.8-fold (0.25 log units) below the measured one; the range from low to high includes it.
By their numbers in this assay, from the lowest: compound 2; then compound 3; then compound 4; then compound 1.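

In this assay the position on the aromatic ring, para to a large group, is not indifferent to which halogen it carries: the change from 4-chlorophenyl to 4-fluorophenyl gives a 2.5-fold higher number from compound 3 to compound 4 (0.40 log units; beyond the scatter). Among the compounds shown here, this is the first one-place comparison at this position in the set, and it shows that replacing one heavy atom with another, with no ring, hydrogen-bond donor, hydrogen-bond acceptor or net charge entering or leaving, can be enough to carry the number past the usual scatter, with chloro giving the stronger inhibition of the two. Nothing measured here accounts for the difference between these two halogens.

The compounds shown leave open where bromo, methoxy or a plain hydrogen at this place would fall relative to chloro and fluoro, so one pair cannot establish a trend across substituents. They also leave open whether the same halogen swap would have a similar size on the longer chain of compound 1 and compound 2, since neither of those compounds forms a one-place pair with compound 3 or compound 4.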